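Nitroimidazooxazine series: metabolic stability across biaryl substituents

A few compounds are considered here, and "the series" means these few. Any claim that something is new, unique, unknown or untested is made for them only; others in the source may bear on it.

Measured so far in an ADME assay on microsomes from liver (Homo sapiens) for metabolic stability, read by LC-MS, with a stated time of 1 h; a higher number here means that more of the compound is left, a lower number that less of the compound is left:
- compound 1 `O=[N+]([O-])c1cn2c(n1)OC[C@@H](OCc1ccc(-c3ccc(C(F)(F)F)cc3)cc1)C2`: 60%
- compound 2 `O=[N+]([O-])c1cn2c(n1)OC[C@@H](OCc1ccc(-c3ccc(OC(F)(F)F)cc3)cc1)C2`: 97%
- compound 3 `O=[N+]([O-])c1cn2c(n1)OC[C@@H](OCc1ccc(-c3ccc(Cl)c(OC(F)(F)F)c3)cc1)C2`: 95%

Compound 2 and compound 3 both stand high in this assay; their values are within the scatter of each other. The difference between the core of compound 2 and the core of compound 3 is not broken down here. Between compound 2 and compound 1 the change is trifluoromethyl in place of trifluoromethoxy on an aromatic carbon and the step is a number 37 percentage points lower from compound 2 to compound 1 (beyond the scatter).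

Compound 4 `O=[N+]([O-])c1cn2c(n1)OC[C@@H](OCc1ccc(-c3ccc(Cl)c(C(F)(F)F)c3)cc1)C2` is not yet measured. It differs from compound 3 by trifluoromethyl in place of trifluoromethoxy on an aromatic carbon. This is the same kind of change as from compound 2 to compound 1, though the surroundings differ: in compound 1 the group is para to a large group, whereas in compound 4 it is ortho to a chloro group and meta to a large group.

Among the measured compounds shown here, for compound 4 a step of about a number 35 percentage points lower from compound 3 to compound 4 (beyond the scatter) is expected, because a number 37 percentage points lower from compound 2 to compound 1 (beyond the scatter) is the only precedent for this change. Compound 4 is therefore estimated at 60%, between 40% and 82%.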

Compound 4, percent of the compound remaining: 92%
Estimate against measurement, compound 4: 32 percentage points below; the whole stated range lies below it.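

In this assay, trifluoromethyl in place of trifluoromethoxy gives a number 3 percentage points lower from compound 3 to compound 4 (within the scatter). The size of this change therefore does not carry over from one core to the other: the same change on two cores in this assay, a number 37 percentage points lower (beyond the scatter) from compound 2 to compound 1 and a number 3 percentage points lower (within the scatter) from compound 3 to compound 4, 34 percentage points apart, beyond the scatter of two such steps

Two pairs cannot show whether the chloro group or the different place of the change accounts for the gap, and they give no rule for the step on a further core.

Still open, going by these compounds, is how a nitrile, a methoxy group or an amine at this place would fare in this assay. Also open, on these data alone, is whether the chloro group alone, with neither fluorinated group present, would give a value like that of compound 4.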